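Trading a Urea Chain for a Phenol

This account rests on a few compounds, and the source may have more. Where it says the series, first, only, none or still open, it means among the compounds named here.

Measured compounds:
compound 1 `COc1cc(NC(C)CCCNC(=O)NNC(=O)Nc2ccc(F)cc2)c2ncccc2c1`: >= 250000 nM
compound 2 `COc1cc(NC(C)CCCNC(=O)NNC(=O)Nc2ccc(Br)cc2)c2ncccc2c1`: 101000 nM
compound 3 `COc1cc(NC(C)CCCNC(=O)Nc2cccc(C(F)(F)F)c2)c2ncccc2c1`: 14000 nM

In a functional assay on HeLa cells (Homo sapiens) for inhibition, read by MTT assay, with a stated time of 72 h (on this read-out lower numbers stand for stronger inhibition and higher numbers for weaker inhibition), compound 1 gives >= 250000 nM, which is a limit of the assay rather than a number, so compound 1 stands only at the limit of >= 250000 nM in this assay, at which 1 of the 3 values shown sits. Compound 4 `COc1cc(NC(C)CCCNC(=O)Nc2ccc(O)cc2)c2ncccc2c1` has not yet been measured; it differs from compound 1 by 4-hydroxyphenyl in place of ((4-fluorophenyl)carbamoyl)amino on an amide-type nitrogen. Going by the values given here, two measured steps bear on this change, as both remove the same carbamoylamino link and put an aryl group directly on the nitrogen: an at least 17-fold lower number from compound 1 to compound 3 (1.25 log units; beyond the scatter) and a 7.2-fold lower number from compound 2 to compound 3 (0.86 log units; beyond the scatter). A step of similar direction, though carrying a hydroxy group rather than trifluoromethyl, is therefore expected for compound 4: an at least 6.2-fold lower number from compound 1 to compound 4 (0.79 log units; beyond the scatter). Compound 4 is estimated at about 40000 nM, likely between 10000 nM and 200000 nM.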

Compound 4, half-maximal inhibitory concentration: 70000 nM
Beside the measured number, compound 4's estimate is 1.8-fold (0.24 log units) below it; low and high end bracket the measured number.
By their numbers in this assay, from the lowest: compound 3; then compounds 4 and 2 (each within the scatter of the next). At a limit, above all of these: compound 1.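

In this assay, removing the carbamoylamino link does not by itself bring a clear gain, since a 1.4-fold lower number from compound 2 to compound 4 (0.16 log units; within the scatter). The other step from a chain compound, an at least 3.5-fold lower number from compound 1 to compound 4 (0.55 log units; beyond the scatter), has only a limit at its start: the limit of >= 250000 nM in this assay, at which 1 of the 4 values shown sits. With the link gone from both compounds, the aryl group on the amide-type nitrogen still matters, as a 5.0-fold higher number from compound 3 to compound 4 (0.70 log units; beyond the scatter). From the compounds shown here alone, whether 4-aminophenyl or 4-carboxyphenyl on that nitrogen would fall nearer compound 3 or compound 4 stays open. So does whether the group itself or its place on the ring carries that last step.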